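From 4-fluorophenyl to 2-(trifluoromethyl)phenyl on a shared core

The source may hold more compounds than are shown below. What is called first, only, known or untested is meant among the compounds shown, and "the series" means these compounds.

In an ADME assay on HEK-293T cells (Homo sapiens) for cytotoxicity, read by MTT assay, with a stated time of 3 days (on this read-out higher numbers stand for lower toxicity in this test and lower numbers for higher toxicity in this test), compound 1 `CC(C)(C)N(CCC(=O)c1ccccc1)C(=O)COC(=O)c1ccc([N+](=O)[O-])o1` gives "not active" (no number reported) as its reading. Compound 2 `CC(C)(C)N(Cc1ccc(F)cc1)C(=O)COC(=O)c1ccc([N+](=O)[O-])o1` stands at > 100000 nM which is a limit of the assay and not a number. Compound 3 `CC(C)(C)N(Cc1ccccc1C(F)(F)F)C(=O)COC(=O)c1ccc([N+](=O)[O-])o1` is the next analogue to be tested. The change 2-(trifluoromethyl)phenyl in place of 4-fluorophenyl on a saturated chain carbon bound to an amide-type nitrogen puts 2-(trifluoromethyl)phenyl in place of 4-fluorophenyl on a saturated chain carbon bound to an amide-type nitrogen. Among the compounds with values here, no measured step between compounds is available, so no step beyond the scatter is expected in this assay in either direction. The expected a number no higher from compound 2 to compound 3 (the limit leaves the size open) is thus small. For compound 3 the estimate is 100000 nM with an expected range that has 40000 nM as its lower end and 200000 nM as its upper end.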

Compound 3, half-maximal cytotoxic concentration: 65000 nM
For compound 3 the middle estimate is 1.5-fold (0.19 log units) above the measured one, within the range that was stated.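

In this assay, 2-(trifluoromethyl)phenyl in place of 4-fluorophenyl on a saturated chain carbon bound to an amide-type nitrogen gives an at least 1.5-fold lower number from compound 2 to compound 3 (0.18 log units; that floor lies within the scatter). Compound 3 thereby supplies the first true number among the compounds shown, so this place can yield a reading inside the range of the assay. Compound 2 carries only a limit of the assay and not a number, so the full size of the step stays open: the limit of > 100000 nM in this assay, at which 1 of the 3 values shown sits.

The compounds shown leave open how an amine or a carboxylic acid would read at this place on the shared core.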